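The source may hold more compounds than are shown below. What is called first, only, known or untested is meant among the compounds shown, and "the series" means these compounds.

Going by the values given here, compound 2 `CCOC(=O)c1cnc(NC2CC2)n2nc(-c3ccco3)nc12` gives the lowest number among the two compounds measured so far in an assay on CHO cells for displacement of a labelled ligand from adenosine receptor A3 (Homo sapiens); a higher number here means a weaker inhibitor, a lower number a stronger inhibitor; in this assay compound 2 gives 9.52 nM. Its nearest neighbour is compound 1 `COc1ccc(CNc2ncc(C(=O)O)c3nc(-c4ccco4)nn23)cc1OC`, which in this assay gives 159 nM, a gap beyond the usual scatter, though the two share no single-point difference from which a step could be read. Compound 3 `CCOC(=O)c1cnc(N2CCCCC2)n2nc(-c3ccco3)nc12` has not yet been measured. It differs from compound 2 in one place: piperidin-1-yl in place of cyclopropylamino on an aromatic carbon. The secondary amine on the shared core is thereby replaced by a ring nitrogen carrying no hydrogen. Among the compounds with values here, with no measured step of this kind to rest on, the expectation is that compound 3 will give a higher number than compound 2, a step of a 6.3-fold higher number from compound 2 to compound 3 (0.80 log units; beyond the scatter) in this assay, beyond the scatter. Compound 3 is therefore estimated at 60 nM, within a range from 10 nM to 400 nM.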

Compound 3, inhibition constant: 1770 nM
For compound 3 the middle estimate is 30-fold (1.47 log units) below the measured one; the measured number lies above the stated range.
By their numbers in this assay, from the lowest: compound 2; then compound 1; then compound 3.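

Piperidin-1-yl in place of cyclopropylamino on the aromatic carbon between two ring nitrogen atoms brings a 190-fold higher number from compound 2 to compound 3 (2.27 log units; beyond the scatter) in this assay, so the earlier compounds' lack of a single-point comparison gives way to a first sign that this position is far from indifferent to the group it carries. The change replaces a group with 1 hydrogen-bond donor by one with 0 and also goes from 4 heavy atoms to 6, so this one step cannot separate the loss of the amine hydrogen from the change in ring and size. No measurement is available that bears on why the number rises so far.

On these data alone, it remains open whether an open-chain amine such as ethylamino, or a larger ring on a secondary amine such as cyclohexylamino, would stay near compound 2. As far as these compounds go, it is also open whether the same step would appear with a carboxylic acid in place of the ethoxycarbonyl group.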